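Oxadiazole-thioether hydrazones: fluoro to nitro on the phenyl ring

The source may report more compounds than this note shows. Statements on the series, on what has been measured and on what is new or still open speak of the compounds shown alone.

Measured compounds in a functional assay on MCF7 cells (Homo sapiens) for cytotoxicity, read by MTT assay, with a stated time of 48 h; a higher number here means a weaker inhibitor, a lower number a stronger inhibitor:
compound 1 `O=C(CSc1nnc(-c2ccncc2)o1)N/N=C/c1ccc(F)cc1` gives 13500 nM
compound 2 `O=C(CSc1nnc(-c2ccncc2)o1)N/N=C/c1ccc([N+](=O)[O-])cc1` gives 31800 nM
compound 3 `O=C(CSc1nnc(-c2ccncc2)o1)N/N=C/c1ccccc1F` gives 21800 nM

The shared core carries a phenyl ring on the carbon with a double bond to nitrogen; compound 1 and compound 2 differ only there, by nitro in place of fluoro on an aromatic carbon, and this gives a 2.4-fold higher number from compound 1 to compound 2 (0.37 log units; beyond the scatter). Compound 1 and compound 3 have the same atoms joined differently, (2-fluorophenyl in place of 4-fluorophenyl on a carbon with a double bond to nitrogen), and the step is a 1.6-fold higher number from compound 1 to compound 3 (0.21 log units; within the scatter). Compound 2 against compound 3 reads a 1.5-fold lower number from compound 2 to compound 3 (0.16 log units; within the scatter).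

Compound 4 `O=C(CSc1nnc(-c2ccncc2)o1)N/N=C/c1ccccc1[N+](=O)[O-]` is not yet measured. It differs from compound 3 by nitro in place of fluoro on an aromatic carbon. The change from compound 1 to compound 2 sits para to a large group, here it sits ortho to a large group, so this is the same kind of change, not the same one.

Going by the values given here, the expected step from compound 3 to compound 4 in this assay is a 1.9-fold higher number from compound 3 to compound 4 (0.28 log units; within the scatter), resting on the single earlier instance because of a 2.4-fold higher number from compound 1 to compound 2 (0.37 log units; beyond the scatter). Compound 4 is thus expected near 42000 nM, estimated between 18000 nM and 100000 nM.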

Compound 4, half-maximal inhibitory concentration: 35600 nM
For compound 4 the middle estimate is 1.2-fold (0.07 log units) above the measured one; low and high end bracket the measured number.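

In this assay, nitro in place of fluoro on the 2-fluorophenyl compound gives a 1.6-fold higher number from compound 3 to compound 4 (0.21 log units; within the scatter), and the two instances of this change agree in size: the same change on two cores in this assay, a 2.4-fold higher number (0.37 log units; beyond the scatter) from compound 1 to compound 2 and a 1.6-fold higher number (0.21 log units; within the scatter) from compound 3 to compound 4, 1.4-fold (0.16 log units) apart, within the scatter of two such steps

The change therefore carries from the 4-substituted to the 2-substituted phenyl compounds with the same direction of the number, but this rests on only two instances, one of them within the scatter, and does not fix a size for the step or extend to other cores. Moving the nitro gives a 1.1-fold higher number from compound 2 to compound 4 (0.05 log units; within the scatter), so the position of the nitro group is not resolved here, while a 2.6-fold higher number from compound 1 to compound 4 (0.42 log units; beyond the scatter) is the only new step beyond the scatter.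

The compounds shown leave open whether the step holds when the fluoro or nitro group is replaced by a different group, such as an amine or a carboxylic acid. They also leave open whether it survives a change elsewhere in the shared core, such as a longer chain between the sulfur and the carbonyl.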